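A Cyano Group Replaces Bromine on the Sulfonyl Ring

The compounds below may be only part of what the source reports. "The series", "measured", "known", "first", "only" and "open" are said of these compounds alone.

Compound 1 `Cc1ccc(S(=O)(=O)N2C/C(=C\c3ccccc3F)C(=O)/C(=C/c3ccccc3F)C2)cc1`: 4100 nM
Compound 2 `O=C1/C(=C/c2ccccc2F)CN(S(=O)(=O)c2ccc(O[N+](=O)[O-])cc2)C/C1=C\c1ccccc1F`: 6200 nM
Compound 3 `O=C1/C(=C/c2ccccc2F)CN(S(=O)(=O)c2ccc(Br)cc2)C/C1=C\c1ccccc1F`: 5200 nM

These three compounds share one core and differ only in the group on the aromatic ring attached to the sulfonyl. In a functional assay on SMMC-7721 cells (Homo sapiens) for cytotoxicity, read by MTT assay, with a stated time of 24 h (a higher number here means a weaker inhibitor, a lower number a stronger inhibitor), compound 1 gives 4100 nM, compound 2 gives 6200 nM, and compound 3 gives 5200 nM. Compound 3 holds the second highest of the three numbers, and both neighbours sit close to it: a 1.2-fold lower number from compound 2 to compound 3 (0.08 log units; within the scatter) and a 1.3-fold higher number from compound 1 to compound 3 (0.10 log units; within the scatter). The remaining pair is no different: a 1.5-fold higher number from compound 1 to compound 2 (0.18 log units; within the scatter).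

Compound 4 `N#Cc1ccc(S(=O)(=O)N2C/C(=C\c3ccccc3F)C(=O)/C(=C/c3ccccc3F)C2)cc1` carries the next change at the same position: cyano in place of bromo on an aromatic carbon. All three measured steps swap one group for another at this very spot, and none of them moves the number beyond the scatter, so the expectation for this assay is again a step that cannot be told from noise. Compound 4 is therefore estimated at 5000 nM, with a range from 2500 nM to 10000 nM. The expected step is a 1.0-fold lower number from compound 3 to compound 4 (0.02 log units; within the scatter).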

Compound 4, half-maximal inhibitory concentration: 14600 nM
Compound 4: the middle estimate sits 2.9-fold (0.47 log units) below what was measured; the measured number lies above the stated range.
By their numbers in this assay, from the lowest: compounds 1, 3 and 2 (each within the scatter of the next); then compound 4.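

For the compounds shown here, until now, swapping one group for another at this position produced nothing that could be told from noise, and cyano is the first group to shift the number in this assay (a 2.8-fold higher number from compound 3 to compound 4 (0.45 log units; beyond the scatter)). The shift holds against the other two groups as well (a 2.4-fold higher number from compound 2 to compound 4 (0.37 log units; beyond the scatter); a 3.6-fold higher number from compound 1 to compound 4 (0.55 log units; beyond the scatter)), which makes compound 4 the weakest inhibitor of the four. The number at this position can therefore move, though the steps are modest and the only shift seen so far is toward a weaker inhibitor.

Nothing available here explains why cyano stands apart from methyl, bromo and nitrooxy. From the compounds shown here alone, it also remains open whether an amine, a carboxylic acid or a longer chain at this position would give a stronger inhibitor or a weaker one.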